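Fluoro in place of hydrogen on an aryl piperazine

The source may hold more compounds than are shown below. What is called first, only, known or untested is meant among the compounds shown, and "the series" means these compounds.

Measured compounds:
Compound 1 `COCC(C(=O)N1CCN(c2cccc(C(F)(F)F)c2)CC1)N1C(=O)CCC1=O`: 75%
Compound 2 `CCC(C(=O)N1CCN(c2ccccc2)CC1)N1C(=O)CCC1=O`: 25%
Compound 3 `CC(C(=O)N1CCN(c2ccc(Cl)cc2)CC1)N1C(=O)CCC1=O`: 25%

Of the compounds shown here, three sharing one core have been tested in a functional assay on the whole organism (strain Swiss) with Mus musculus as the target, in the maximal electroshock model, with a stated time of 0.5 h, at a dose of 100 mg/kg by the intraperitoneal route; a lower number here means a weaker effect, a higher number a stronger effect of the compound at the dose given. Compound 1 `COCC(C(=O)N1CCN(c2cccc(C(F)(F)F)c2)CC1)N1C(=O)CCC1=O` gives 75%. Compound 2 `CCC(C(=O)N1CCN(c2ccccc2)CC1)N1C(=O)CCC1=O` gives 25%, and compound 3 `CC(C(=O)N1CCN(c2ccc(Cl)cc2)CC1)N1C(=O)CCC1=O` gives 25%. Compound 2 and compound 3 stand level at the digits shown, together the lowest of the three; compound 1 stands well above both, beyond the usual scatter. Compound 1 differs from compound 2 in more than one place, so its higher number cannot be assigned to any single change.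

Compound 4 `CCC(C(=O)N1CCN(c2cccc(F)c2)CC1)N1C(=O)CCC1=O` has not yet been measured in this assay. It differs from compound 2 as follows: fluoro in place of hydrogen on an aromatic carbon. The new group sits on an aromatic carbon of a six-membered aromatic ring of carbon only, meta to a large group. For the measured compounds named here, no step between measured compounds isolates this change. Compound 4 is therefore expected to show only a small step from compound 2, a number 10 percentage points higher from compound 2 to compound 4 (within the scatter), upward if at all, and likely within the scatter. Compound 4 is estimated at 35%, with a range from 10% to 65%.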

Compound 4, a percentage reported as activity, at one dose (the size of the read-out at that dose, not a potency): 0%
Compound 4: the middle estimate sits 35 percentage points above what was measured; the measured number lies below the stated range.
By their numbers in this assay, from the lowest: compound 4; then compounds 2 and 3 (each within the scatter of the next); then compound 1.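

In this assay the change from phenyl to 3-fluorophenyl reads (a number 25 percentage points lower from compound 2 to compound 4 (beyond the scatter)), so even a single fluoro on this aromatic carbon moves the read-out by more than the usual scatter, and downward. For the compounds shown here, this is the first step that isolates one change, as the earlier compounds differed from each other in more than one place and could not show what a lone group on this ring does. Nothing measured here bears on why the number falls.

From the compounds shown here alone, whether the fall belongs to fluoro itself or would follow any group on this carbon stays open, as a methyl or a methoxy group in the same place would tell. Also open, going by these compounds, is whether fluoro on another carbon of the same ring would give a similar step.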